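The source may report more compounds than this note shows. Statements on the series, on what has been measured and on what is new or still open speak of the compounds shown alone.

Measured compounds:
compound 1, `CC(O)(COc1ccc(C#N)cc1)C(=O)Nc1ccc(S(F)(F)(F)(F)F)cc1`: 100000 nM
compound 2, `CC(O)(COc1ccc(C#N)c(F)c1)C(=O)Nc1ccc(S(F)(F)(F)(F)F)cc1`: 100000 nM
compound 3, `CC(O)(COc1ccc(C#N)cc1)C(=O)Nc1cccc(S(F)(F)(F)(F)F)c1`: 26600 nM

These three compounds were tested in a functional assay on VCaP cells (Homo sapiens) for antiproliferative activity, read by propidium iodide staining, with a stated time of 96 h; on this read-out higher numbers stand for weaker inhibition and lower numbers for stronger inhibition. Compound 1 and compound 2 share a core and differ only in one respect: fluoro in place of hydrogen on an aromatic carbon. The step that this change made, no change at the digits printed from compound 1 to compound 2 (within the scatter), shows that adding the fluoro there left the read-out where it was. Compound 3 carries the same atoms as compound 1, joined differently; the difference between the two cores is not broken down here. In this assay compound 3 gives 26600 nM, the lowest number of the three, and its gap to compound 1 and to compound 2 is beyond the usual scatter of repeated measurements, so compound 3 is the strongest inhibitor among the measured compounds.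

Compound 4, `CC(O)(COc1ccc(C#N)c(F)c1)C(=O)Nc1cccc(S(F)(F)(F)(F)F)c1`, has not yet been measured. It stands to compound 3 as compound 2 stands to compound 1: fluoro in place of hydrogen on an aromatic carbon. The surroundings of the change are described in the same words in both pairs, so this is the same change made on the core of compound 3. Because the earlier step of no change at the digits printed from compound 1 to compound 2 (within the scatter) was flat, the expectation for the step from compound 3 to compound 4 in this assay is also small, no change at the digits printed from compound 3 to compound 4 (within the scatter), resting on that single earlier pair. On this basis compound 4 is estimated to give about 26600 nM, with a plausible range from 10000 nM to 80000 nM.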

Compound 4, half-maximal inhibitory concentration: 91900 nM
For compound 4 the middle estimate is 3.5-fold (0.54 log units) below the measured one; the measured number lies above the stated range.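

In this assay, the swap of hydrogen for fluoro, which turns a 4-cyanophenyl into a 4-cyano-3-fluorophenyl, did not behave the same way on the two cores: the same change on two cores in this assay, no change at the digits printed (within the scatter) from compound 1 to compound 2 and a 3.5-fold higher number (0.54 log units; beyond the scatter) from compound 3 to compound 4, 3.5-fold (0.54 log units) apart, beyond the scatter of two such steps. On the core of compound 3 the change costs activity, with a 3.5-fold higher number from compound 3 to compound 4 (0.54 log units; beyond the scatter), whereas on the core of compound 1 it left the read-out untouched, with no change at the digits printed from compound 1 to compound 2 (within the scatter), so a flat result on one core was a poor guide to the other in this series. These two pairs show only that the outcome of this change depends on the core that carries it; they do not show why, and they cannot say how the same change would behave on any further core.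

The compounds shown leave open whether the loss on the core of compound 3 is particular to fluoro, since no other group, such as chloro, methyl or methoxy, appears ortho to the cyano group on that core. They also leave open what would happen if the cyano group itself gave way to an amide or a carboxylic acid, on either core.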